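The compounds below may be only part of what the source reports. "The series", "measured", "known", "first", "only" and "open" are said of these compounds alone.

Working notes on the series.

Of the compounds shown here, three have been measured in a functional assay on SF-295 cells (Homo sapiens) for inhibition, read by sulforhodamine B assay, with a stated time of 48 h; on this read-out higher numbers stand for weaker inhibition of growth and lower numbers for stronger inhibition of growth. Compound 1 `COc1ccc2[nH]c(-c3ccccc3)c(C=C(C#N)C#N)c2c1` gives 4200 nM. Compound 2 `COc1ccc(-c2[nH]c3ccc(OC)cc3c2C=C(C#N)C#N)cc1` gives 306 nM. Compound 3 `COc1ccc2[nH]c(-c3ccccc3)c(/C=C(\C#N)S(=O)(=O)c3ccccc3)c2c1` gives 2800 nM, which stands near that of compound 1 and is well apart from that of compound 2.

One structural change recurs. From compound 2 to compound 1 the change is hydrogen in place of methoxy on an aromatic carbon, and it brings a 14-fold higher number from compound 2 to compound 1 (1.14 log units; beyond the scatter). The same kind of change separates compound 3 from compound 4 `N#C/C(=C\c1c(-c2ccccc2)[nH]c2ccccc12)S(=O)(=O)c1ccccc1`, not yet measured in this assay: hydrogen in place of methoxy on an aromatic carbon. The two places are not the same word for word: in the pair of compound 2 and compound 1 the methoxy sits para to a large group, whereas in the pair of compound 3 and compound 4 it sits on a ring that is part of a fused or bridged system of two rings, meta to a fused ring and para to a fused ring. The difference between the core of compound 2 and the core of compound 3 is not broken down here.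

For the measured compounds named here, for compound 4 a weaker effect than compound 3 is expected, because the only measured instance of this kind of change, a 14-fold higher number from compound 2 to compound 1 (1.14 log units; beyond the scatter), went toward higher numbers, though the different place and the single precedent leave the size open, so the expected step is a 2.1-fold higher number from compound 3 to compound 4 (0.33 log units; beyond the scatter). Compound 4 is estimated at 6000 nM, within 1800 nM to 20000 nM.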

Compound 4, concentration for 50% growth inhibition: 2400 nM
Compound 4: the middle estimate sits 2.5-fold (0.40 log units) above what was measured; measured number inside the range.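

In this assay, replacing methoxy with hydrogen on the core of compound 3 gives a 1.2-fold lower number from compound 3 to compound 4 (0.07 log units; within the scatter), so this core shows no measurable response to the change at this place. The large step seen on the core of compound 2 therefore does not carry over to the core of compound 3, and the change cannot be treated as having one transferable size across this series: the same change on two cores in this assay, a 14-fold higher number (1.14 log units; beyond the scatter) from compound 2 to compound 1 and a 1.2-fold lower number (0.07 log units; within the scatter) from compound 3 to compound 4, 16-fold (1.20 log units) apart, beyond the scatter of two such steps. This does not show why the two steps differ, since the pairs differ both in where the methoxy sits and in the core around it, and one pair on each core cannot separate these two differences or show how general either result is.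

The compounds shown leave open whether the methoxy on the ring that is part of the fused system would matter on the core of compound 2, and whether the methoxy that separates compound 2 from compound 1 would have the same large step on the core of compound 3. They also leave open whether a different group at the place where compound 3 carries its methoxy, such as a hydroxyl, an amine or a carboxylic acid, would move the number away from that of compound 3 and compound 4.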